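The source may hold more compounds than are shown below. What is called first, only, known or untested is meant among the compounds shown, and "the series" means these compounds.

Measured so far in an assay on cells for agonist activity at ecdysone receptor (Bombyx mori), read by a luciferase reporter, with a stated time of 24 h; a lower number here means that less compound is needed, a higher number that more compound is needed for the effect:
compound 1, `CCc1ccc(C(=O)NN(C(=O)c2ccccc2)C(C)(C)C)cc1`, gives 4.9 nM;
compound 2, `CCCCCC(=O)N(NC(=O)c1ccc(CC)cc1)C(C)(C)C`, gives 2820 nM.

Among the compounds with values here, compound 2 stands highest of the two numbers in this assay; its only neighbour is compound 1, and the single measured step, a 580-fold higher number from compound 1 to compound 2 (2.76 log units; beyond the scatter), is large. Compound 3, `CCCCCCC(=O)N(NC(=O)c1ccc(CC)cc1)C(C)(C)C`, is not yet measured. It differs from compound 2 by methyl in place of hydrogen on a saturated chain carbon, five bonds along the chain from a carbonyl carbon. Within the data shown here, the one measured step concerns the exchange of a ring for a chain on the carbonyl carbon, not the length of that chain, so it bears on the new step only loosely: it shows that this position matters, but gives no precedent for adding one carbon to an existing chain. With no direct guide, the expected outcome for compound 3 is a step within the usual scatter, a 1.3-fold lower number from compound 2 to compound 3 (0.11 log units; within the scatter). Compound 3 is therefore estimated at 2200 nM, with a range from 600 nM to 7000 nM.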

Compound 3, half-maximal effective concentration: 11700 nM
Compound 3: the middle estimate sits 5.3-fold (0.73 log units) below what was measured, outside the stated range (above it).
By their numbers in this assay, from the lowest: compound 1; then compound 2; then compound 3.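

Chain length on this carbonyl carbon is a variable in its own right in this assay: methyl in place of hydrogen, five bonds along the chain from a carbonyl carbon, gives a modest step beyond the scatter (a 4.1-fold higher number from compound 2 to compound 3 (0.62 log units; beyond the scatter)), whereas the earlier compounds showed only the exchange of phenyl for a chain. Hexyl in place of phenyl gives a wider gap (a 2400-fold higher number from compound 1 to compound 3 (3.38 log units; beyond the scatter)) than pentyl in place of phenyl (a 580-fold higher number from compound 1 to compound 2 (2.76 log units; beyond the scatter)), so the longer of these two chains lies further from compound 1. Nothing available here accounts for this direction of change.

Going by these compounds, two chains fix no trend, so it remains open whether a shorter chain such as propyl or a longer chain such as octyl continues this direction. Also open, on these data alone, is whether a cyclohexyl ring on this carbonyl carbon, or an amine or carboxylic acid at the end of the chain, would stand nearer to compound 1.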